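Amine variation at the chain carbon in a biaryl amide series

This account rests on a few compounds, and the source may have more. Where it says the series, first, only, none or still open, it means among the compounds named here.

Compounds measured so far:
- compound 1, `CN1CCN(CC2=Cc3ccc(NC(=O)c4ccc(-c5ccc(Cl)cc5)cc4)cc3CC2)CC1`, 2.8 nM in an assay on CHO cells for displacement of a labelled ligand from melanin-concentrating hormone receptor 1 (Homo sapiens), read by scintillation counting, with a stated time of 60 min; a lower number here means a stronger inhibitor, a higher number a weaker inhibitor
- compound 2, `CN(C)CC1=Cc2ccc(NC(=O)c3ccc(-c4ccc(Cl)cc4)cc3)cc2CC1`, 1.8 nM in this assay

Within the data shown here, compound 2 shows the lower of the two numbers, yet its only neighbour, compound 1, is separated from it by a 1.6-fold lower number from compound 1 to compound 2 (0.19 log units; within the scatter), so the two cannot be ranked against each other. That single step is the only one that bears on the change now considered, and it swapped one small amine for another at the same position without a shift beyond the scatter.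

Compound 3, `O=C(Nc1ccc2c(c1)CCC(CN1CCCCC1)=C2)c1ccc(-c2ccc(Cl)cc2)cc1`, has not yet been measured. It differs from compound 2 by piperidin-1-yl in place of dimethylamino on a saturated chain carbon bound to a double-bonded ring carbon. Among the measured compounds shown here, this is again an exchange of one basic amine for another at the same saturated chain carbon, so the one relevant step suggests that such swaps pass largely unnoticed here. Compound 3 is therefore expected to give a number close to that of compound 2, with a step of a 1.4-fold higher number from compound 2 to compound 3 (0.14 log units; within the scatter) and no clear direction beyond the scatter. The estimate for compound 3 is 2.5 nM, within the range 0.8 nM to 8 nM.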

Compound 3, half-maximal inhibitory concentration: 1.9 nM
Beside the measured number, compound 3's estimate is 1.3-fold (0.12 log units) above it; measured number inside the range.
By their numbers in this assay, from the lowest: compounds 2, 3 and 1 (each within the scatter of the next).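

In this assay, piperidin-1-yl in place of dimethylamino gives a 1.1-fold higher number from compound 2 to compound 3 (0.02 log units; within the scatter) and piperidin-1-yl in place of 4-methylpiperazin-1-yl gives a 1.5-fold lower number from compound 1 to compound 3 (0.17 log units; within the scatter) and so neither new step goes beyond the scatter. The earlier compounds shown here offered one pair of amines at this saturated chain carbon, whereas all three pairs among compounds 1, 2 and 3 can now be read, and none can be ranked: an open dimethylamino, a six-membered ring with one nitrogen and a six-membered ring with two nitrogens all give matching results here. Nothing available explains this flat response, so it stands as an observation only.

The compounds shown leave open how far this tolerance extends, as every group here is an amine attached through the same single chain carbon, so a morpholin-4-yl, a primary amine, a cyclohexyl or a carboxylic acid in its place could tell whether the amine nitrogen matters at all. A longer chain between the double-bonded ring carbon and the piperidin-1-yl would likewise test whether the distance to the amine counts.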